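This account rests on a few compounds, and the source may have more. Where it says the series, first, only, none or still open, it means among the compounds named here.

Measured so far:
compound 1 `CC(C)C/N=c1\c(O)c(O)\c1=N/Cc1ccc(C#N)cc1`, 10200 nM
compound 2 `CCC(C)(C)/N=c1\c(O)c(O)\c1=N/Cc1ccc(C)cc1C`, 530 nM
compound 3 `CCC/N=c1\c(O)c(O)\c1=N/Cc1ccc(C#N)cc1`, 21900 nM

The three compounds share one core and differ in the group on the imine nitrogen and in the benzyl ring. Compound 2 has the lowest number in a functional assay for inhibition, with Rattus norvegicus as the target; a higher number here means a weaker inhibitor, a lower number a stronger inhibitor; compound 1 and compound 3 lie well above it. The difference between the core of compound 2 and the core of compound 1 is not broken down here.

Among the compounds with values here, the one change measured within the set is hydrogen in place of methyl on a saturated chain carbon bound to two saturated chain carbons, which gave a 2.1-fold higher number from compound 1 to compound 3 (0.33 log units; beyond the scatter). Compound 4 `Cc1ccc(C/N=c2\c(O)c(O)\c2=N/C(C)(C)C)c(C)c1` is not yet measured. From compound 2 it is reached by hydrogen in place of methyl on a saturated chain carbon, two bonds along the chain from a double-bonded nitrogen. Within the data shown here, this is the same kind of change as the one from compound 1 to compound 3, not the same: there the carbon is bound to two saturated chain carbons, here it sits two bonds along the chain from a double-bonded nitrogen, and the benzyl ring is different in the two pairs.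

Among the measured compounds shown here, for compound 4 in this assay, a step of the same direction and similar size is expected, resting on a 2.1-fold higher number from compound 1 to compound 3 (0.33 log units; beyond the scatter) as the only measured instance of this kind of change. The expected step is a 1.9-fold higher number from compound 2 to compound 4 (0.28 log units; within the scatter). The estimate for compound 4 is 1000 nM, between 400 nM and 2500 nM.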

Compound 4, half-maximal inhibitory concentration: 630 nM
Beside the measured number, compound 4's estimate is 1.6-fold (0.20 log units) above it; the range from low to high includes it.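

In this assay, going from 1,1-dimethylpropyl to tert-butyl gives a 1.2-fold higher number from compound 2 to compound 4 (0.08 log units; within the scatter), so on this core the change cannot be told apart from repeat scatter. Set beside the earlier step, the two cores show no measurable difference: the same change on two cores in this assay, a 2.1-fold higher number (0.33 log units; beyond the scatter) from compound 1 to compound 3 and a 1.2-fold higher number (0.08 log units; within the scatter) from compound 2 to compound 4, 1.8-fold (0.26 log units) apart, within the scatter of two such steps. This supports carrying the hydrogen-for-methyl change from one core to the other as a small step at most, but two pairs do not fix its size, and they cannot separate the effect of the core from that of the carbon carrying the change or of the benzyl ring.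

From the compounds shown here alone, it remains open whether the same change on the tert-butyl or 1,1-dimethylpropyl chain would give a similar step with the nitrile-bearing benzyl ring in place. Also open, going by these compounds, is how a longer chain, a cyclohexyl ring or a carboxylic acid on the chain at the double-bonded nitrogen would behave.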